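This account rests on a few compounds, and the source may have more. Where it says the series, first, only, none or still open, it means among the compounds named here.

Measured in an ADME assay on MT4 cells (Homo sapiens) for cytotoxicity, read by MTT assay, with a stated time of 4 days; on this read-out lower numbers stand for higher toxicity in this test and higher numbers for lower toxicity in this test:
- compound 1 `CC(=O)Nc1ccc2oc(-c3ccc(F)cc3)c(O)c(=O)c2c1`: 34100 nM
- compound 2 `COc1c(-c2ccccc2F)oc2ccc(NC(C)=O)cc2c1=O`: 180000 nM
- compound 3 `COc1c(-c2cccc(F)c2)oc2ccc(NC(C)=O)cc2c1=O`: 210000 nM

Compound 3, at 210000 nM, lies within the usual scatter of compound 2. Both numbers stand clearly apart from the lower one of compound 1, at 34100 nM, which means higher toxicity in this test.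

The next compound, compound 4 `COc1c(-c2ccc(F)cc2)oc2ccc(NC(C)=O)cc2c1=O`, has not yet been measured. It has the same atoms as compound 3, joined differently: 4-fluorophenyl in place of 3-fluorophenyl on an aromatic carbon. Put simply, 4-fluorophenyl stands in place of 3-fluorophenyl on an aromatic carbon, next to the ring oxygen and ortho to a methoxy group.

For the measured compounds named here, only one measured step bears on this change, and it is of the same kind, with 3-fluorophenyl in place of 2-fluorophenyl: a 1.2-fold higher number from compound 2 to compound 3 (0.07 log units; within the scatter). Going by the values given here, no single measured step connects compound 1 to the other two, so it offers no direct guide. A single small step is thin evidence, but it gives no reason to expect a shift in either direction beyond the scatter.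

The expected result is a 1.1-fold lower number from compound 3 to compound 4 (0.02 log units; within the scatter), which would be no real change.

For compound 4 the estimated value is 200000 nM, with an expected range from 110000 nM to 320000 nM.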

Compound 4, half-maximal cytotoxic concentration: 317000 nM
Compound 4: the middle estimate sits 1.6-fold (0.20 log units) below what was measured; measured number inside the range.
By their numbers in this assay, from the lowest: compound 1; then compounds 2, 3 and 4 (each within the scatter of the next).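

In this assay the fluorine can sit on any of the three phenyl positions shown without the number leaving the usual scatter: a 1.5-fold higher number from compound 3 to compound 4 (0.18 log units; within the scatter) and a 1.8-fold higher number from compound 2 to compound 4 (0.25 log units; within the scatter) are both small steps, so 2-fluorophenyl, 3-fluorophenyl and 4-fluorophenyl cannot be told apart here. Compound 4 also gives the first link between compound 1 and the methylated compounds that differs in one place: a 9.3-fold higher number from compound 1 to compound 4 (0.97 log units; beyond the scatter) is a step beyond the scatter, so methyl in place of hydrogen on the oxygen goes with lower toxicity in this test, a shift that moving the fluorine does not produce. Nothing measured here explains either observation.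

This single pair cannot show whether the same methyl change would give a similar step with 2-fluorophenyl or 3-fluorophenyl in place, or whether a longer chain such as ethyl on that oxygen would do the same. On these data alone, it also remains open whether a different group on the phenyl ring, such as an amine or a carboxylic acid, would stay as close to these numbers as the fluorine isomers do.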